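The source may hold more compounds than are shown below. What is called first, only, known or untested is meant among the compounds shown, and "the series" means these compounds.

Measured so far: compound 1 `CN(C)CCn1cnnc1-c1cc(Oc2ccc(NC(=O)N/N=C/c3c(Cl)cccc3Cl)cc2F)ccn1` gives 1410 nM in a functional assay on A549 cells (Homo sapiens) for cytotoxicity, read by MTT assay, with a stated time of 72 h; a lower number here means a stronger inhibitor, a higher number a weaker inhibitor; compound 2 `COc1ccc(/C=N/NC(=O)Nc2ccc(Oc3ccnc(-c4nncn4CCN(C)C)c3)c(F)c2)c(OC)c1` gives 2820 nM in this assay.

Going by the values given here, compound 2 stands alongside compound 1 rather than apart from it: the only step between them, a 2.0-fold higher number from compound 1 to compound 2 (0.30 log units; within the scatter), is within the scatter, so the two numbers cannot be told apart with confidence.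

Compound 3 `CN(C)CCn1cnnc1-c1cc(Oc2ccc(NC(=O)N/N=C/c3ccc(O)c(Br)c3)cc2F)ccn1` is the next compound, and it differs from compound 2 at a single place: 3-bromo-4-hydroxyphenyl in place of 2,4-dimethoxyphenyl on a carbon with a double bond to nitrogen. Among the compounds with values here, the one measured step that bears on this change is the earlier exchange of the aromatic ring at this same position, a 2.0-fold higher number from compound 1 to compound 2 (0.30 log units; within the scatter), which stayed within the scatter. Within the data shown here, only one such step exists, and the group that enters brings a hydrogen-bond donor where the group that leaves had none, so the ground for an expectation is thin. On what is shown, no step beyond the scatter is expected in this assay, that is a 1.4-fold lower number from compound 2 to compound 3 (0.15 log units; within the scatter). Compound 3 is therefore estimated at 2000 nM in this assay. The expected range for compound 3 runs from 600 nM to 7000 nM.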

Compound 3, half-maximal inhibitory concentration: 1370 nM
For compound 3 the middle estimate is 1.5-fold (0.16 log units) above the measured one; the measured number falls inside the stated range.
By their numbers in this assay, from the lowest: compounds 3, 1 and 2 (each within the scatter of the next, the first and the last beyond it).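

At the aromatic ring on a carbon with a double bond to nitrogen, this assay now gives a step that passes the scatter, though only modestly: 3-bromo-4-hydroxyphenyl in place of 2,4-dimethoxyphenyl gives a 2.1-fold lower number from compound 2 to compound 3 (0.31 log units; beyond the scatter), whereas the earlier exchange at this place stayed within the scatter. The same entering ring in place of 2,6-dichlorophenyl gives a 1.0-fold lower number from compound 1 to compound 3 (0.01 log units; within the scatter), so compound 1 and compound 3 cannot be told apart even though only compound 3 carries a hydroxy group, and that group alone therefore does not mark out the lower numbers in this small set. Nothing shown here gives a measured reason for the step from the dimethoxy ring to the bromo-hydroxy ring.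

The bromine and the hydroxy group enter together, so the compounds shown leave open which of them goes with the step, a question that 3-bromophenyl and 4-hydroxyphenyl at this place could separate. Also open, on these data alone, is how far the numbers would move with a group of another kind here, such as a carboxylic acid, an amine or a saturated cyclohexyl ring.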